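Chain extension at the ethoxy carbon of compound 1

The source may hold more compounds than are shown below. What is called first, only, known or untested is meant among the compounds shown, and "the series" means these compounds.

Compound 1 `CCOc1c(-c2cc(OC)c(OC)c(OC)c2)oc2ccccc2c1=O` is the reference point of this set. In a functional assay on PC-3 cells (Homo sapiens) for antiproliferative activity, read by WST assay, with a stated time of 3 days (a lower number here means a stronger inhibitor, a higher number a weaker inhibitor), compound 1 gives 900 nM, the lowest of the three numbers measured. Compound 2 `CCCCOc1c(-c2cc(OC)c(OC)c(OC)c2)oc2ccccc2c1=O` gives 12800 nM in this assay, and compound 3 `CCCN(CCC)CCCCOc1c(-c2cc(OC)c(OC)c(OC)c2)oc2ccccc2c1=O` gives 11600 nM. Compound 4 `CCCCN(CCCC)CCCCCOc1c(-c2cc(OC)c(OC)c(OC)c2)oc2ccccc2c1=O` is not yet measured; it differs from compound 1 as follows: 3-(dibutylamino)propyl in place of hydrogen on a saturated chain carbon, two bonds along the chain from an oxygen on an aromatic ring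

Among the measured compounds shown here, two measured steps bear on this change, since both also build onto the same saturated chain carbon of compound 1: a 14-fold higher number from compound 1 to compound 2 (1.15 log units; beyond the scatter) and a 13-fold higher number from compound 1 to compound 3 (1.11 log units; beyond the scatter). Both were large losses of similar size. The further step a 1.1-fold lower number from compound 2 to compound 3 (0.04 log units; within the scatter) shows that a dipropylamino group at the end of the extended chain neither added to nor removed from that loss. The change to compound 4 again lengthens the chain at the same place, with 3-(dibutylamino)propyl in place of hydrogen, so a loss of comparable size is expected. The estimate for compound 4 in this assay is 12000 nM, with a range of 4000 nM to 40000 nM. That estimate means an expected step of a 13-fold higher number from compound 1 to compound 4 (1.12 log units; beyond the scatter).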

Compound 4, half-maximal inhibitory concentration: 6800 nM
Compound 4: the middle estimate sits 1.8-fold (0.25 log units) above what was measured, within the range that was stated.
By their numbers in this assay, from the lowest: compound 1; then compounds 4, 3 and 2 (each within the scatter of the next).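

Even with 3-(dibutylamino)propyl on this saturated chain carbon, the number stays well away from that of the shared reference in this assay (a 7.6-fold higher number from compound 1 to compound 4 (0.88 log units; beyond the scatter)), so all three extensions shown lie beyond the scatter of compound 1. The dibutylamino end group adds nothing that can be separated from the dipropylamino analogue (a 1.7-fold lower number from compound 3 to compound 4 (0.23 log units; within the scatter)) or from the plain butoxy chain (a 1.9-fold lower number from compound 2 to compound 4 (0.27 log units; within the scatter)), which extends the reading that an amine at the chain end makes no measurable difference to the longer chain with dibutylamino as well. No supporting data on why this extension costs activity accompany these numbers.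

The compounds shown leave open how a propoxy chain would read at this carbon, since the smallest extension here is already the butoxy chain. Also open, as far as these compounds go, is whether a dimethylamino, morpholine or carboxylic acid end group would read any differently from the dialkylamino groups.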